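The source may hold more compounds than are shown below. What is called first, only, known or untested is meant among the compounds shown, and "the series" means these compounds.

Of the compounds shown here, three sharing one core have been measured in an assay on isolated protein for inhibition of protein kinase C zeta type (Homo sapiens), with a stated time of 4 min, tested at 62.5 uM; on this read-out lower numbers stand for less inhibition and higher numbers for more inhibition at the one concentration tested (going by the name of the read-out). Compound 1 `CC(C)(C)C1=NN(c2ccc(Br)cc2)C(c2ccc(O)cc2)C1` gives 93.2%, compound 2 `CC(C)(C)C1=NN(c2cccc(Cl)c2)C(c2ccc(O)cc2)C1` gives 96.8%, and compound 3 `CC(C)(C)C1=NN(c2cccc(C(F)(F)F)c2)C(c2ccc(O)cc2)C1` gives 96.1%. Compound 2 holds the highest of the three numbers, yet its separation from the other two is small: the step from compound 1 to compound 2 is a number 3.6 percentage points higher from compound 1 to compound 2 (within the scatter), and the step from compound 2 to compound 3 is a number 0.7 percentage points lower from compound 2 to compound 3 (within the scatter), both within the scatter.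

Compound 4 `CC(C)(C)C1=NN(c2ccccc2Cl)C(c2ccc(O)cc2)C1` has not yet been measured. It differs from compound 2 in one place, (2-chlorophenyl in place of 3-chlorophenyl on an amine nitrogen in a ring). The two measured steps are the ones that bear on this change, since each of them alters the group on the same ring nitrogen, and neither moved the number beyond the scatter. No step beyond the scatter is therefore expected in this assay. Compound 4 is expected to give about 94%, within a range from 85% to 99%. The expected step from compound 2 to compound 4 is a number 2.8 percentage points lower from compound 2 to compound 4 (within the scatter).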

Compound 4, a percentage reported as inhibition, at one concentration (the size of the read-out at that concentration, not a potency): 57.1%
Compound 4: middle estimate off by 36.9 percentage points, on the high side; measured number below the stated range.
By their numbers in this assay, from the lowest: compound 4; then compounds 1, 3 and 2 (each within the scatter of the next).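

In this assay, for the compounds shown here, 2-chlorophenyl in place of 3-chlorophenyl gives a number 39.7 percentage points lower from compound 2 to compound 4 (beyond the scatter) on the ring nitrogen, and since the leaving and entering groups hold the same atoms, where the chlorine sits on the phenyl ring is the only difference behind this step. The step of a number 36.1 percentage points lower from compound 1 to compound 4 (beyond the scatter) is of similar size, so compound 4 also stands well apart from the 4-bromophenyl compound, whereas the earlier changes at this nitrogen stayed within the scatter. At this position, then, a change that keeps the atoms the same can matter far more than the earlier swaps of one group for another, though no measurement here explains the drop.

From the compounds shown here alone, whether the drop belongs to chlorine itself or would also come with 2-fluorophenyl, 2-methylphenyl or 2-methoxyphenyl remains open. Also open, going by these compounds, is whether the same drop would appear if the 4-hydroxyphenyl group were replaced by another group, such as 4-aminophenyl.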